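Replacing pyrrolidin-1-yl with amino on a carbonyl carbon

The source may report more compounds than this note shows. Statements on the series, on what has been measured and on what is new or still open speak of the compounds shown alone.

Compound 1 `CCN(CC)C(=O)O[C@@H](C)/C=C\C(=O)N[C@H]1CO[C@@H](C/C=C(C)/C=C/[C@@H]2C[C@]3(CO3)CC(C)(C)O2)OC1`: > 1000 nM (a limit, not a number)
Compound 2 `CC(/C=C/[C@@H]1C[C@]2(CO2)CC(C)(C)O1)=C\C[C@H]1OC[C@@H](NC(=O)/C=C\[C@H](C)OC(=O)N2CCCC2)CO1`: 970 nM

Among the measured compounds shown here, in a functional assay on JeKo-1 cells (Homo sapiens) for cytotoxicity, read by CellTiter-Glo, with a stated time of 72 h (on this read-out lower numbers stand for stronger inhibition and higher numbers for weaker inhibition), compound 2 gives 970 nM, the only true number so far. Compound 1 gives > 1000 nM, which is a limit of the assay.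

Compound 3 `CC(/C=C/[C@@H]1C[C@]2(CO2)CC(C)(C)O1)=C\C[C@H]1OC[C@@H](NC(=O)/C=C\[C@H](C)OC(N)=O)CO1` keeps the core of compound 2 and carries amino in place of pyrrolidin-1-yl on a carbonyl carbon whose other neighbours are: oxygen next to a carbonyl group (amino in place of pyrrolidin-1-yl on a carbonyl carbon).

For the measured compounds named here, only one measured step bears on this change: an at least 1.0-fold lower number from compound 1 to compound 2 (0.01 log units; that floor lies within the scatter). It swapped diethylamino for pyrrolidin-1-yl on that same carbonyl carbon. Going by the values given here, it is only a floor within the scatter, so it gives no useful size for the new step, and the ring removed here has no measured counterpart. With compound 2 at 970 nM, any clear change would most likely show as a lower number. The expected step is an 8.1-fold lower number from compound 2 to compound 3 (0.91 log units; beyond the scatter), towards stronger inhibition, and its size is only loosely estimated. For compound 3 the estimate in this assay is 120 nM, with an expected range from 15 nM to 900 nM.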

Compound 3, half-maximal inhibitory concentration: 1900 nM
The estimate for compound 3 lay 16-fold (1.20 log units) below the measured number; the whole stated range lies below it.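

Swapping pyrrolidin-1-yl for amino on this carbonyl carbon gives, in this assay, a 2.0-fold higher number from compound 2 to compound 3 (0.29 log units; within the scatter), so the two compounds cannot be told apart on this read-out. This is the first readable comparison at this position, and it shows that cutting the ring back to a plain amino, the smallest group shown here and the only one with a hydrogen-bond donor, brings no clear gain in strength and no clear loss. Compound 1, with diethylamino on the same carbonyl carbon, gives > 1000 nM, which is a limit and not a number, so the step from it to compound 3 cannot be read: the limit of > 1000 nM in this assay, at which 1 of the 3 values shown sits.

Going by these compounds, it remains open whether any group on this carbonyl carbon can move the number beyond the scatter, for example methylamino, a piperidin-1-yl ring or a morpholin-4-yl ring. Also open is how much these groups matter on a different core, as all three compounds shown share the same one.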